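The source may hold more compounds than are shown below. What is called first, only, known or untested is meant among the compounds shown, and "the series" means these compounds.

Working notes on the series, with all readings taken from an ADME assay on HEK293 cells (Homo sapiens) for cytotoxicity, read by resazurin assay, with a stated time of 48 h; on this read-out higher numbers stand for lower toxicity in this test and lower numbers for higher toxicity in this test. Among the measured compounds shown here, compound 1 (`C=Cc1ccc(S(=O)(=O)Nc2ccc3oc(-c4ccccc4)nc3c2)cc1`) gives 53000 nM, the only true number available so far. Compound 2 (`O=S(=O)(Nc1ccc(-c2nc3ccccc3o2)cc1)c1cccc(O)c1`) reads > 100000 nM, which is a limit of the assay and not a number. Compound 1 is therefore the sole numeric anchor, and no ranking can be drawn beyond what these two readings show.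

The next compound to be read is compound 3 (`COc1ccccc1S(=O)(=O)Nc1ccc2oc(-c3ccccc3)nc2c1`), which keeps the core of compound 1 and carries 2-methoxyphenyl in place of 4-vinylphenyl on a sulfonyl sulfur. For the measured compounds named here, no measured pair isolates this exchange, so its size in this assay has to be judged without a direct precedent. The expectation rests on compound 1 at 53000 nM. It rests as well on compound 2, whose reading of > 100000 nM is a limit of the assay. On that thin basis, the expected result is a 1.3-fold higher number from compound 1 to compound 3 (0.12 log units; within the scatter), a change that stays within the usual scatter and leans, if anything, toward lower toxicity. For compound 3 the estimated value is 70000 nM, with an expected range of 30000 nM to 100000 nM.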

Compound 3, half-maximal cytotoxic concentration: 41000 nM
Estimate against measurement, compound 3: 1.7-fold (0.23 log units) above; the measured number falls inside the stated range.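

Among the compounds shown here, the exchange of 4-vinylphenyl for 2-methoxyphenyl on a sulfonyl sulfur, in this assay, gives a 1.3-fold lower number from compound 1 to compound 3 (0.11 log units; within the scatter), and this is the first step that can be read. The two groups differ in their count of double bonds outside aromatic rings and of hydrogen-bond acceptors, yet this exchange shows no order between them, so at this position and on this core the reading does not separate them. Compound 2 reads at a limit of the assay and not at a number, so no step to it can be read: the limit of > 100000 nM in this assay, at which 1 of the 3 values shown sits.

Open, going by these compounds, is whether an amine or a carboxylic acid on the phenyl ring at this sulfonyl sulfur, or a longer alkyl chain in place of that ring, would give a step beyond the scatter in this assay. Also open, on these data alone, is whether the exchange of 4-vinylphenyl for 2-methoxyphenyl would read the same way on a core other than that of compound 1.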